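The source may hold more compounds than are shown below. What is called first, only, known or untested is meant among the compounds shown, and "the series" means these compounds.

Measured compounds:
Compound 1, `COc1cc2nc(N3CCCN(C(=O)N4CCOCC4)CC3)nc(N)c2c(-c2ccccn2)c1OC`: 41 mL/min/kg
Compound 2, `COc1cc2nc(N3CCCN(C(=O)N4CCOCC4)CC3)cc(N)c2c(-c2ccccc2)c1OC`: 122 mL/min/kg

In an in vitro ADME assay on microsomes from liver (Canis lupus familiaris) for metabolic stability, tested at 1 uM (on this read-out lower numbers stand for slow clearance and higher numbers for fast clearance), compound 2 gives the highest of the two numbers shown, and compound 1 gives a clearly lower one; the two are not related by a single change, so no measured step exists between them. Compound 3, `COc1cc2nc(N3CCCN(C(=O)N4CCOCC4)CC3)cc(N)c2c(-c2ccc(F)cc2)c1OC`, differs from compound 2 by fluoro in place of hydrogen on an aromatic carbon. Among the compounds with values here, no measured pair shows this change, so there is nothing to lean on. The expected step is a modest decrease, a 1.4-fold lower number from compound 2 to compound 3 (0.13 log units; within the scatter), which may not exceed the usual scatter. Compound 3 is estimated at 90 mL/min/kg, within 45 mL/min/kg to 180 mL/min/kg.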

Compound 3, clearance: 100 mL/min/kg
The estimate for compound 3 lay 1.1-fold (0.05 log units) below the measured number; the range from low to high includes it.
By their numbers in this assay, from the lowest: compound 1; then compounds 3 and 2 (each within the scatter of the next).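

This is the only pair shown that differs in one place. In this assay, going from phenyl to 4-fluorophenyl gives a 1.2-fold lower number from compound 2 to compound 3 (0.09 log units; within the scatter), so this single fluoro, on an aromatic carbon para to a large group, gives no change that can be told apart from repeat-measurement noise. Nothing measured alongside these compounds offers an explanation for this result. Still open, as far as these compounds go, is whether a different group on this carbon, such as an amine or a nitrile, would shift the clearance beyond the scatter.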